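This account rests on a few compounds, and the source may have more. Where it says the series, first, only, none or still open, it means among the compounds named here.

Working notes on the tetrazole series. Of the compounds shown here, three have numbers so far in a functional assay on H4 cells for agonist activity at growth hormone secretagogue receptor type 1 (Homo sapiens), read by FLIPR; a higher number here means that more compound is needed for the effect, a lower number that less compound is needed. Compound 1 `COC(=O)C(c1ccccc1)n1nnnc1[C@@H](COCc1ccccc1)NC(=O)C(C)(C)N` gives 20 nM and stands lowest of the three. Compound 2 `CC(C)(N)C(=O)N[C@H](COCc1ccccc1)c1nnn(Cc2ccc(NS(C)(=O)=O)cc2)n1` gives 986 nM and compound 3 `CC(C)(N)C(=O)N[C@H](COCc1ccccc1)c1nnn(CC2Cc3ccccc3N2S(C)(=O)=O)n1` gives 546 nM; both differ from compound 1 in more than one place, so their gaps to compound 1 are read only as what the two values show, each well beyond the scatter.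

The next compound, compound 4 `CCCCNC(=O)CCn1nnnc1[C@@H](COCc1ccccc1)NC(=O)C(C)(C)N`, changes the group on the ring nitrogen: 2-(butylcarbamoyl)ethyl in place of methoxycarbonyl)(benzyl on an aromatic nitrogen. Among the compounds with values here, no single-site step of this kind has been measured, so the direction is an expectation only. Because compound 1 carries the lowest value at 20 nM, and the aromatic ring leaves, a loss is expected, moderate in size, as a 7.5-fold higher number from compound 1 to compound 4 (0.88 log units; beyond the scatter). Compound 4 is therefore estimated at 150 nM, within 30 nM to 800 nM.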

Compound 4, half-maximal effective concentration: 42 nM
For compound 4 the middle estimate is 3.6-fold (0.55 log units) above the measured one, and the stated range covers the measured number.
By their numbers in this assay, from the lowest: compound 1; then compound 4; then compounds 3 and 2 (each within the scatter of the next).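

At this aromatic nitrogen, the series now has its first single-site step: 2-(butylcarbamoyl)ethyl in place of methoxycarbonyl)(benzyl gives a 2.1-fold higher number from compound 1 to compound 4 (0.32 log units; beyond the scatter) in this assay. The six-membered aromatic ring of carbon can therefore leave this position at the cost of only a modest step. Nothing measured here explains the step.

Still open, on these data alone, is how much of the step belongs to the lost ring, the lost methoxycarbonyl or the entering amide. A plain benzyl, a shorter alkyl chain or a carboxylic acid at this position would help separate these.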